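The source may report more compounds than this note shows. Statements on the series, on what has been measured and on what is new or still open speak of the compounds shown alone.

Measured compounds:
Compound 1 `CN(C(=O)NC(=O)c1ccc(C(F)(F)F)cc1)c1nc(C(F)(F)F)c(C(=O)N/N=C/c2cccc(C(F)(F)F)c2)s1`: 6.2 ug/mL
Compound 2 `CN(C(=O)NC(=O)c1c(F)cccc1F)c1nc(C(F)(F)F)c(C(=O)N/N=C/c2ccccc2C(F)(F)F)s1`: 19.6 ug/mL
Compound 3 `CN(C(=O)NC(=O)c1cccc([N+](=O)[O-])c1)c1nc(C(F)(F)F)c(C(=O)N/N=C/c2ccccc2C(F)(F)F)s1`: 4.15 ug/mL

All three were tested in a functional assay on HeLa cells (Homo sapiens) for inhibition, read by MTT assay, with a stated time of 72 h; a lower number here means a stronger inhibitor, a higher number a weaker inhibitor. Compound 3 shows the lowest number of the three, yet its gap to compound 1 lies within the scatter; only compound 2 sits clearly apart, as the step of a 4.7-fold lower number from compound 2 to compound 3 (0.67 log units; beyond the scatter) shows. Compound 4 `CN(C(=O)NC(=O)c1ccc(C(F)(F)F)cc1)c1nc(C(F)(F)F)c(C(=O)N/N=C/c2ccccc2C(F)(F)F)s1` has not been measured. It differs from compound 3 by 4-(trifluoromethyl)phenyl in place of 3-nitrophenyl on a carbonyl carbon. Going by the values given here, no measured step covers this exact exchange. Among the compounds with values here, the one step at the carbonyl carbon, a 4.7-fold lower number from compound 2 to compound 3 (0.67 log units; beyond the scatter), moved the number modestly. Compound 1 carries the same 4-(trifluoromethyl)phenyl group on its carbonyl carbon and gives 6.2 ug/mL, close to compound 3. The step to compound 4 is therefore expected to be small, a 1.6-fold higher number from compound 3 to compound 4 (0.19 log units; within the scatter), in either direction within the scatter. Compound 4 is expected to give about 6.5 ug/mL, between 2.5 ug/mL and 17 ug/mL.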

Compound 4, half-maximal inhibitory concentration: 3.76 ug/mL
Compound 4: the middle estimate sits 1.7-fold (0.24 log units) above what was measured; the measured number falls inside the stated range.
By their numbers in this assay, from the lowest: compounds 4, 3 and 1 (each within the scatter of the next); then compound 2.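

In this assay, 4-(trifluoromethyl)phenyl in place of 3-nitrophenyl on the carbonyl carbon gives a 1.1-fold lower number from compound 3 to compound 4 (0.04 log units; within the scatter) and so cannot be told apart, although the two groups share only their six-membered aromatic ring, while 2,6-difluorophenyl stays clearly separate, with a 5.2-fold lower number from compound 2 to compound 4 (0.72 log units; beyond the scatter) for its exchange. On the carbon with a double bond to nitrogen, 2-(trifluoromethyl)phenyl in place of 3-(trifluoromethyl)phenyl gives a 1.6-fold lower number from compound 1 to compound 4 (0.22 log units; within the scatter) and is also not a clear change. No evidence is available that bears on these results. From the compounds shown here alone, whether an unsubstituted phenyl, or a phenyl carrying an amine or a carboxylic acid, would keep the carbonyl-carbon result remains open.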